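Chloro in place of methyl: compound 2 to compound 3

The compounds below may be only part of what the source reports. "The series", "measured", "known", "first", "only" and "open" are said of these compounds alone.

Compound 1 `Cc1ccc(NC(=S)NC(=O)c2ccc(OCc3ccccc3F)cc2)cc1-c1nc2ccccc2[nH]1` and compound 2 `Cc1ccc(NC(=S)NC(=O)c2ccc(OCc3ccc(Cl)cc3Cl)cc2)cc1-c1nc2ccccc2[nH]1` share one core and differ only in the benzyl ether part. In a functional assay on MGC-803 cells (Homo sapiens) for inhibition, read by MTT assay, with a stated time of 48 h (on this read-out lower numbers stand for stronger inhibition and higher numbers for weaker inhibition), compound 1 gives 3070 nM, and in this assay compound 2 gives 3450 nM; the step of a 1.1-fold higher number from compound 1 to compound 2 (0.05 log units; within the scatter) is within the scatter, so the two numbers cannot be separated, and compound 2 stands with compound 1 at the same level on the numbers shown.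

Compound 3 `O=C(NC(=S)Nc1ccc(Cl)c(-c2nc3ccccc3[nH]2)c1)c1ccc(OCc2ccc(Cl)cc2Cl)cc1` differs from compound 2 by chloro in place of methyl on an aromatic carbon, on an aromatic carbon of a six-membered aromatic ring of carbon only, ortho to a 1H-benzimidazol-2-yl group and para to a large group. Going by the values given here, the single measured step of a 1.1-fold higher number from compound 1 to compound 2 (0.05 log units; within the scatter) concerns a different part of the molecule and says nothing about this ring, so no measured step bears on the change.

With no guide from the series, compound 3 is expected to stay near compound 2, a step of a 1.0-fold higher number from compound 2 to compound 3 (0.01 log units; within the scatter) that need not exceed the scatter. Compound 3 is therefore estimated at 3500 nM in this assay, within 1400 nM to 9000 nM.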

Compound 3, half-maximal inhibitory concentration: 3030 nM
Beside the measured number, compound 3's estimate is 1.2-fold (0.06 log units) above it; the range from low to high includes it.
By their numbers in this assay, from the lowest: compounds 3, 1 and 2 (each within the scatter of the next).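

At the aromatic carbon ortho to a 1H-benzimidazol-2-yl group and para to a large group, chloro in place of methyl gives a 1.1-fold lower number from compound 2 to compound 3 (0.06 log units; within the scatter) in this assay and so the two groups cannot be told apart at this position. Going by these compounds alone, this is the first reading on this ring, since the earlier step concerned only the benzyl ether part, and with the 2,4-dichlorophenyl ether held fixed the change leaves the number within the scatter. Nothing available explains this result.

Among the compounds shown, this carbon carries only methyl or chloro, so whether a methoxy group, an amine or a carboxylic acid here would give a step beyond the scatter remains open. No step shown so far lies beyond the scatter, so which change on either part of the molecule can move the number also remains open.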